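Swapping chloro for trifluoromethyl on a second anilino ring

The compounds below may be only part of what the source reports. "The series", "measured", "known", "first", "only" and "open" are said of these compounds alone.

Of the compounds shown here, three of one family have been tested in a functional assay on HT-29 cells (Homo sapiens) for antiproliferative activity, read by MTT assay, with a stated time of 48 h; on this read-out higher numbers stand for weaker inhibition and lower numbers for stronger inhibition. Compound 1 `O=C(/C=C\Nc1ccc(Cl)cc1)c1cn(-c2ccccc2)nc1-c1ccccc1` gives 3610 nM. Compound 2 `O=C(/C=C\Nc1ccc(C(F)(F)F)cc1)c1cn(-c2ccccc2)nc1-c1ccccc1` differs from it by trifluoromethyl in place of chloro on an aromatic carbon. For compound 2 the assay reports only a limit, > 50000 nM, which is the limit of > 50000 nM in this assay, at which 1 of the 3 values shown sits. The change from compound 1 to compound 2 therefore produced an at least 13-fold higher number from compound 1 to compound 2 (1.14 log units; beyond the scatter).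

Compound 3 `O=C(/C=C\Nc1ccc(Cl)cc1)c1cn(-c2ccccc2)nc1-c1ccc(Cl)cc1` carries a different core than compound 1; the two cores differ by chloro in place of hydrogen on an aromatic carbon. In this assay compound 3 gives 4650 nM, and the step is a 1.3-fold higher number from compound 1 to compound 3 (0.11 log units; within the scatter), so compounds 1 and 3 cannot be told apart on this read-out.

Compound 4 `O=C(/C=C\Nc1ccc(C(F)(F)F)cc1)c1cn(-c2ccccc2)nc1-c1ccc(Cl)cc1` has not been measured. It differs from compound 3 by trifluoromethyl in place of chloro on an aromatic carbon. The place of this change is described in the same words as for the change from compound 1 to compound 2, so it is the same change, made on the core of compound 3 instead of the core of compound 1. Since the two cores give numbers within the scatter of each other, the expectation rests on the earlier step: the change is expected to cost roughly as much again, about a 15-fold higher number from compound 3 to compound 4 (1.18 log units; beyond the scatter), because an at least 13-fold higher number from compound 1 to compound 2 (1.14 log units; beyond the scatter). Compound 4 is estimated at 70000 nM, with a range of 15000 nM to 300000 nM, and there is a fair chance the assay will again report only a limit.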

Compound 4, half-maximal inhibitory concentration: > 50000 nM
Compound 4: only a limit was reported; the forecaster's own chance of this, stated with the estimate: 65%; the middle value lies beyond the limit too.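

In this assay compound 4 also returns only a limit, > 50000 nM. Replacing (4-chlorophenyl)amino with (4-(trifluoromethyl)phenyl)amino on the core of compound 3 gives an at least 10-fold higher number from compound 3 to compound 4 (1.03 log units; beyond the scatter), so the large loss of antiproliferative activity seen on the core of compound 1 appears on this second core too, and the two results can be set side by side: the same change on two cores in this assay, an at least 13-fold higher number (1.14 log units; beyond the scatter) from compound 1 to compound 2 and an at least 10-fold higher number (1.03 log units; beyond the scatter) from compound 3 to compound 4; the limit leaves it open whether they differ This shows that the loss carried over to the one other core tested, but the true size of the loss remains unknown on both cores, and the step from compound 2 to compound 4, which adds chloro to the core, cannot be read, so nothing can be said about how that chloro acts once trifluoromethyl is present: the limit of > 50000 nM in this assay, at which 2 of the 4 values shown sit.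

Going by these compounds, it remains open whether this steep loss is specific to trifluoromethyl or would also follow from other groups in the same place, such as fluoro, methoxy, a nitrile or an amine. On these data alone, it is also open whether a group other than chloro on the core, such as methoxy or a carboxylic acid, would leave the numbers as little changed as chloro did.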